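Swapping phenyl for pyridin-2-yl on the ring nitrogen

This account rests on a few compounds, and the source may have more. Where it says the series, first, only, none or still open, it means among the compounds named here.

Among the compounds with values here, compound 2 `Cn1cc(C2=C(c3nn(CCCN4CCCCC4)c4ncccc34)C(=O)N(c3ccccc3)C2=O)c2ccccc21` is the only compound here with a plain number: in a functional assay on ECa-109 cells (Homo sapiens) for antiproliferative activity, read by MTT assay, with a stated time of 48 h (on this read-out lower numbers stand for stronger inhibition and higher numbers for weaker inhibition), compound 2 gives 12300 nM. Compound 1 `Cn1cc(C2=C(c3nn(CCCn4cncn4)c4ncccc34)C(=O)N(c3ccccc3)C2=O)c2ccccc21` reaches only a limit of the assay; in this assay compound 1 gives > 100000 nM. Within the data shown here, the single measured step, an at least 8.1-fold lower number from compound 1 to compound 2 (0.91 log units; beyond the scatter), concerns the end of the chain, not the ring nitrogen. Compound 3 `Cn1cc(C2=C(c3nn(CCCN4CCCCC4)c4ncccc34)C(=O)N(c3ccccn3)C2=O)c2ccccc21` differs from compound 2 by pyridin-2-yl in place of phenyl on an amide-type nitrogen in a ring. Among the measured compounds shown here, no measured step touches this place, so the expected step of a 1.0-fold lower number from compound 2 to compound 3 (0.01 log units; within the scatter) is none beyond the scatter. Compound 3 is therefore estimated at 12000 nM, within a range from 5000 nM to 30000 nM.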

Compound 3, half-maximal inhibitory concentration: 7300 nM
Compound 3: middle estimate off by 1.6-fold (0.22 log units), on the high side; the range from low to high includes it.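

Within the data shown here, the first measured step at this place, on an amide-type nitrogen in a ring, is small: pyridin-2-yl in place of phenyl gives a 1.7-fold lower number from compound 2 to compound 3 (0.23 log units; within the scatter). In this assay, this place therefore accepts a ring nitrogen and a hydrogen-bond acceptor without a change that can be told from the scatter. Nothing measured here bears on what lies behind this result.

From the compounds shown here alone, whether pyridin-3-yl, pyridin-4-yl or a phenyl carrying chlorine or methoxy would behave alike stays open. So does the outcome of the same swap with the 1H-1,2,4-triazol-1-yl chain end of compound 1.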